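Swapping the morpholine amide of compound 3 for an ethyl ester

The source may report more compounds than this note shows. Statements on the series, on what has been measured and on what is new or still open speak of the compounds shown alone.

Measured compounds:
compound 1 `CN1CCN(C(=O)/C=C/c2ccncc2-c2ccc3ccccc3c2)CC1`: 101%
compound 2 `O=C(O)[C@@H]1CCCN1C(=O)/C=C/c1ccncc1-c1ccc2ccccc2c1`: 67%
compound 3 `O=C(/C=C/c1ccncc1-c1ccc2[nH]ccc2c1)N1CCOCC1`: 97%

In an assay on a protein complex for inhibition of CDK8/Cyclin C (Homo sapiens), with a stated time of 1 h, tested at 10 uM (a higher number here means more inhibition at the concentration tested (going by the name of the read-out), a lower number less inhibition), compound 3 gives 97%, the second highest of the three numbers: compound 1 sits within the scatter of it, while compound 2 lies well below it. Compound 4 `CCOC(=O)/C=C/c1ccncc1-c1ccc2[nH]ccc2c1` is not yet measured. It differs from compound 3 only at the carbonyl carbon: ethoxy in place of morpholin-4-yl on a carbonyl carbon.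

Going by the values given here, the one measured step at that same position is the change from the 4-methylpiperazin-1-yl group to the 2-carboxypyrrolidin-1-yl group, which gave a number 34 percentage points lower from compound 1 to compound 2 (beyond the scatter). That step shows the carbonyl carbon substituent can move the number a great deal, though in that case an acid entered, which is not the case here. For compound 4 a moderate decrease is expected, a number 22 percentage points lower from compound 3 to compound 4 (beyond the scatter), with wide uncertainty. Compound 4 is therefore estimated at 75%, within the range 40% to 100%.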

Compound 4, a percentage reported as inhibition, at one concentration (the size of the read-out at that concentration, not a potency): 100%
Compound 4: middle estimate off by 25 percentage points, on the low side, within the range that was stated.
By their numbers in this assay, from the lowest: compound 2; then compounds 3, 4 and 1 (each within the scatter of the next).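

In this assay, the change from morpholin-4-yl to ethoxy on this carbonyl carbon gives a number 3 percentage points higher from compound 3 to compound 4 (within the scatter) and so stays within the usual scatter. On the core of compound 3, then, this position accepts an ester in place of an amide, and the morpholine ring is not needed to keep the number. The large step of a number 34 percentage points lower from compound 1 to compound 2 (beyond the scatter) therefore does not apply to every change at this position.

Going by these compounds, whether a free carboxylic acid or a longer chain such as butoxy would also hold the number on this core stays open. Nothing available here gives a reason for this result.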